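The source may report more compounds than this note shows. Statements on the series, on what has been measured and on what is new or still open speak of the compounds shown alone.

Three compounds share one core and differ in the group on the sulfonamide nitrogen: compound 1 `CC(=O)N1CCN(c2ccc(CN(C(C)(C)C)S(=O)(=O)Cc3ccccc3)cc2)CC1` carries tert-butyl, compound 2 `CCCN(Cc1ccc(N2CCN(C(C)=O)CC2)cc1)S(=O)(=O)Cc1ccccc1` carries propyl and compound 3 `CCN(Cc1ccc(N2CCN(C(C)=O)CC2)cc1)S(=O)(=O)Cc1ccccc1` carries ethyl. In a physicochemical assay for solubility, in phosphate buffer, measured as kinetic solubility, with a stated time of 24 h, at pH 7.4 (a higher number here means a more soluble compound, a lower number a less soluble compound), compound 3 gives 31000 nM. In this assay compound 2 gives 40000 nM, which is within the scatter of compound 3. Compound 1 returns only a limit, <= 1000 nM.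

Exchanging tert-butyl brought large steps, an at least 31-fold higher number from compound 1 to compound 3 (1.49 log units; beyond the scatter) and an at least 40-fold higher number from compound 1 to compound 2 (1.60 log units; beyond the scatter). Compound 4 `CC(=O)N1CCN(c2ccc(CN(CCN(C)C)S(=O)(=O)Cc3ccccc3)cc2)CC1` keeps the ethyl chain of compound 3 but extends it: dimethylamino in place of hydrogen on a saturated chain carbon, two bonds along the chain from a sulfonamide nitrogen, which turns ethyl into 2-(dimethylamino)ethyl. The tert-butyl steps describe a different change, so they are a poor guide here. The closest measured comparison is at the same chain carbon, where the step is small: a 1.3-fold lower number from compound 2 to compound 3 (0.11 log units; within the scatter). Dimethylamino appears in no measured compound, so its effect remains an open question. A modest rise in this assay is expected, not clearly beyond the scatter, with a wide margin of doubt. The expected step is a 1.9-fold higher number from compound 3 to compound 4 (0.29 log units; within the scatter). For compound 4 the estimated value is 60000 nM, with an expected range of 20000 nM to 200000 nM.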

Compound 4, solubility: 221000 nM
The estimate for compound 4 lay 3.7-fold (0.57 log units) below the measured number; measured number outside the range, above it.
By their numbers in this assay, from the lowest: compounds 3 and 2 (each within the scatter of the next); then compound 4. At a limit, below all of these: compound 1.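

In this assay, the swap of hydrogen for methyl at this chain carbon left compounds 2 and 3 within the scatter of each other, but dimethylamino on the same carbon gives a clearer change: a 7.1-fold higher number from compound 3 to compound 4 (0.85 log units; beyond the scatter), and when it takes the place of methyl, a 5.5-fold higher number from compound 2 to compound 4 (0.74 log units; beyond the scatter). This position therefore does not treat all groups alike, since what stands on this carbon can shift the number well beyond the scatter, at least when the incoming group is dimethylamino rather than a small carbon chain. Replacing tert-butyl on the sulfonamide nitrogen with 2-(dimethylamino)ethyl gives an at least 220-fold higher number from compound 1 to compound 4 (2.34 log units; beyond the scatter), though the full size of that step stays unknown, as compound 1 gives only a limit: the limit of <= 1000 nM in this assay, at which 1 of the 4 values shown sits.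

The compounds shown leave open whether the rise belongs to the amine itself or would also come with a longer chain, such as butyl or pentyl. Equally open, going by these compounds, is how a methoxy group, a hydroxyl group or a ring amine such as morpholine would read on the same carbon.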